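The source may report more compounds than this note shows. Statements on the series, on what has been measured and on what is new or still open speak of the compounds shown alone.

Measured so far:
compound 1 `CC(=O)c1cc(C)c(OCCCCC#N)cc1O`, 79%
compound 2 `CCc1cc(C(C)=O)c(O)cc1OCCCCC#N`, 92%
compound 3 `CCCCc1cc(C(C)=O)c(O)cc1OCCCCC#N`, 41%

The three share one core and differ only in the group on a saturated chain carbon bound to an aromatic carbon. In an assay on isolated protein for inhibition of leukotriene B4 receptor 1 (Homo sapiens), tested at 10 uM (a lower number here means less inhibition, a higher number more inhibition at the concentration tested (going by the name of the read-out)), compound 2 gives 92% and stands highest of the three; the nearest is compound 1 with 79%, the furthest compound 3 with 41%. The steps run a number 13 percentage points higher from compound 1 to compound 2 (beyond the scatter), a number 38 percentage points lower from compound 1 to compound 3 (beyond the scatter) and a number 51 percentage points lower from compound 2 to compound 3 (beyond the scatter).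

Compound 4 `CC(=O)c1cc(C=O)c(OCCCCC#N)cc1O` is not yet measured in this assay. Against compound 2 it shows (formyl in place of ethyl on an aromatic carbon). Going by the values given here, none of the measured steps covers this exchange: each lengthens or shortens a saturated chain at that aromatic carbon, whereas here a formyl group replaces the ethyl chain. Those chain steps show that what sits at this aromatic carbon moves the read-out in this assay strongly, with compound 3 far below compound 2, but they give no direction for a formyl group. A moderate fall is therefore expected, a number 22 percentage points lower from compound 2 to compound 4 (beyond the scatter), with wide uncertainty. Compound 4 is expected to give 70% in this assay, within a range from 40% to 92%.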

Compound 4, a percentage reported as inhibition, at one concentration (the size of the read-out at that concentration, not a potency): 6%
The estimate for compound 4 lay 64 percentage points above the measured number, and the stated range ends above it.
By their numbers in this assay, from the lowest: compound 4; then compound 3; then compound 1; then compound 2.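

In this assay, the formyl group gives the largest fall seen at this aromatic carbon, with the read-out running a number 86 percentage points lower from compound 2 to compound 4 (beyond the scatter) and also a number 73 percentage points lower from compound 1 to compound 4 (beyond the scatter) and a number 35 percentage points lower from compound 3 to compound 4 (beyond the scatter) in the same direction. Formyl and ethyl match in heavy atoms, so the size of the group, which could have been read from the chain steps alone, does not order the series: compound 4 stands lowest of the four, even under the butyl compound 3. No measurement bears on the reason for this fall.

A hydroxymethyl or a vinyl group at this carbon would show whether the loss follows the oxygen or the double bond of the formyl group. Going by these compounds, an amine or a carboxylic acid here remains open as well.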